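This account rests on a few compounds, and the source may have more. Where it says the series, first, only, none or still open, it means among the compounds named here.

Series notes. Compound 1 `COc1cc(C(=O)/C=C/c2cn(-c3ccccc3)nc2-c2ccsc2)cc(OC)c1OC` and compound 2 `COc1ccc(C(=O)/C=C/c2cn(-c3ccccc3)nc2-c2ccsc2)c(OC)c1OC` are built from the same atoms joined differently; the difference between the two cores is not broken down here. In a functional assay on HCT-116 cells (Homo sapiens) for inhibition, read by sulforhodamine B assay, with a stated time of 72 h (a higher number here means a weaker inhibitor, a lower number a stronger inhibitor), compound 1 gives 3200 nM, and in this assay compound 2 gives 5800 nM; the two values lie within the scatter of each other. Compound 3 `COc1cc(C(=O)/C=C/c2cn(-c3ccccc3)nc2-c2cccnc2)cc(OC)c1OC` differs from compound 1 by pyridin-3-yl in place of thiophen-3-yl on an aromatic carbon. In this assay compound 3 gives 8600 nM. For the measured compounds named here, the measured step is a 2.7-fold higher number from compound 1 to compound 3 (0.43 log units; beyond the scatter), the only measured instance of this change among the compounds here. The values of compound 2 and compound 3 lie within the scatter of each other, so no order is claimed between them.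

Compound 4 `COc1ccc(C(=O)/C=C/c2cn(-c3ccccc3)nc2-c2cccnc2)c(OC)c1OC` has not been measured. It differs from compound 2 by pyridin-3-yl in place of thiophen-3-yl on an aromatic carbon. The surroundings of the place are the same word for word as for the change from compound 1 to compound 3, so this is the same change, made on the core of compound 2 rather than on the core of compound 1. With a single measured instance, the transfer between cores is not checked by any other pair.

Beside the measured step, the expected step in this assay is a 2.6-fold higher number from compound 2 to compound 4 (0.41 log units; beyond the scatter), resting on a 2.7-fold higher number from compound 1 to compound 3 (0.43 log units; beyond the scatter) applied to compound 2 at 5800 nM.

Compound 4 is estimated in this assay at 15000 nM, within a range from 7000 nM to 35000 nM.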

Compound 4, half-maximal inhibitory concentration: 1100 nM
Compound 4: middle estimate off by 14-fold (1.13 log units), on the high side, outside the stated range (below it).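

In this assay, the replacement of thiophen-3-yl by pyridin-3-yl gives a 5.3-fold lower number from compound 2 to compound 4 (0.72 log units; beyond the scatter), so on the core of compound 2 the step runs in the opposite direction to the one on the core of compound 1, and the size and direction of this change cannot be carried from one core to the other in this series: the same change on two cores in this assay, a 2.7-fold higher number (0.43 log units; beyond the scatter) from compound 1 to compound 3 and a 5.3-fold lower number (0.72 log units; beyond the scatter) from compound 2 to compound 4, 14-fold (1.15 log units) apart, beyond the scatter of two such steps. The result shows that the effect of this change depends on the core it is made on, at least for these two cores, so a step measured on one of them is a poor guide to the other. For the compounds shown here, it does not show what in the difference between the cores produces the reversal, and with only one pair on each core, it gives no general rule for this series and cannot tell how far either step would repeat.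

Going by these compounds, what remains open is whether the dependence on the core extends to other groups at this place on the five-membered ring, such as an amine, a carboxylic acid or a longer chain in place of pyridin-3-yl. Also open, on these data alone, is whether the reversal appears on any core other than these two.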